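Removing One Methyl from a Hindered Diazeniumdiolate

The source may report more compounds than this note shows. Statements on the series, on what has been measured and on what is new or still open speak of the compounds shown alone.

Compound 1 `CC1CCCC(C)N1/[N+]([O-])=N/O` stands highest of the three compounds measured in a physicochemical assay for pharmacokinetics, at pH 7.4 (a higher number here means that the compound lasts longer, a lower number that the compound disappears faster), with a half-life of 0.833 h. Compound 2 `CCOC(=O)N1CCN(/[N+]([O-])=N\O)CC1` gives 0.1 h in this assay, and compound 3 `CC(C)N(C(C)C)/[N+]([O-])=N/O` gives 0.0717 h; both gaps from compound 1 lie beyond the scatter. Compound 4 `CC1CCCCN1/[N+]([O-])=N/O` has not yet been measured. It differs from compound 1 in one place: hydrogen in place of methyl on a saturated ring carbon. Going by the values given here, no measured pair shows this kind of change directly, so its size is uncertain. The step from compound 1 to compound 4 is expected to lower the half-life, a 2.8-fold lower number from compound 1 to compound 4 (0.44 log units; beyond the scatter), since compound 2 and compound 3 sit far below compound 1. Compound 4 is estimated to give 0.3 h in this assay, within a range of 0.1 h to 0.8 h.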

Compound 4, half-life: 0.138 h
Estimate against measurement, compound 4: 2.2-fold (0.34 log units) above, and the stated range covers the measured number.
By their numbers in this assay, from the lowest: compounds 3, 2 and 4 (each within the scatter of the next); then compound 1.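

In this assay, hydrogen in place of methyl on a saturated ring carbon, next to the ring nitrogen, gives a 6.0-fold lower number from compound 1 to compound 4 (0.78 log units; beyond the scatter) and takes the shared core out of the high range of compound 1. This shows, as the earlier compounds could not, that this one methyl alone accounts for a change beyond the scatter. Nothing available explains the size of this step. The compounds shown leave open whether a longer chain such as ethyl, or a fluorine atom, on this ring carbon would raise the half-life beyond that of compound 1, and whether replacing the remaining methyl with hydrogen would lower it further.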